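Cytotoxicity notes: aryl-piperidine exchange on the anilide

The compounds below may be only part of what the source reports. "The series", "measured", "known", "first", "only" and "open" are said of these compounds alone.

Measured so far:
compound 1 `Cc1cc(/C=C/C#N)cc(C)c1Oc1nc(Nc2ccc(CN3CCN(S(C)(=O)=O)CC3)cc2)nc2ccsc12` — 20700 nM
compound 2 `Cc1cc(/C=C/C#N)cc(C)c1Oc1nc(Nc2ccc(N3CCCC(NS(N)(=O)=O)C3)cc2)nc2sccc12` — > 217000 nM

The shared core carries a para-substituted anilino group, and the two compounds differ only in the group at that position. Within the data shown here, in an ADME assay on MT4 cells (Homo sapiens) for cytotoxicity, read by MTT assay, with a stated time of 5 days (a higher number here means that more compound is tolerated, a lower number that less compound is tolerated), compound 1 gives 20700 nM; it is the only compound in the set with a numerical reading. For compound 2 the assay returns > 217000 nM, which is a limit of the assay and not a number; this is the case described in the limit of > 217000 nM in this assay, at which 1 of the 2 values shown sits.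

Compound 3 `Cc1cc(/C=C/C#N)cc(C)c1Oc1nc(Nc2ccc(N3CCCC(NS(C)(=O)=O)C3)cc2)nc2ccsc12` is not yet measured. It differs from compound 1 by 3-(methanesulfonamido)piperidin-1-yl in place of (4-(methylsulfonyl)piperazin-1-yl)methyl on an aromatic carbon, in words: 3-(methanesulfonamido)piperidin-1-yl in place of (4-(methylsulfonyl)piperazin-1-yl)methyl on an aromatic carbon. Among the measured compounds shown here, no step between measured compounds exists to size this change. Compound 2 shows that a piperidin-1-yl group with a sulfonamide-type substituent on the anilide carbon sits at the limit, while compound 1 gives a number, so the expected direction for compound 3 is towards more tolerated, with a step of a 3.1-fold higher number from compound 1 to compound 3 (0.50 log units; beyond the scatter) expected. For compound 3 the estimated value in this assay is 65000 nM, in the range 15000 nM to 217000 nM.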

Compound 3, half-maximal cytotoxic concentration: > 217000 nM
Compound 3 ended at the assay's limit; the forecaster's own chance of this, stated with the estimate: 35%; middle value at least 3.3-fold (0.52 log units) from the limit.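

In this assay, among these compounds, 3-(methanesulfonamido)piperidin-1-yl in place of (4-(methylsulfonyl)piperazin-1-yl)methyl on the aromatic carbon gives an at least 10-fold higher number from compound 1 to compound 3 (1.02 log units; beyond the scatter), the first sized step at this position and the first sign that the group here can move the tolerated concentration. Compound 3 reads > 217000 nM, which is a limit of the assay and not a number, so the step has a floor but no upper end, and the limit now holds more than a single compound: the limit of > 217000 nM in this assay, at which 2 of the 3 values shown sit.

The two groups have the same atoms, joined differently, so the step comes without any gain or loss of atoms; the entering group has one six-membered non-aromatic ring with 1 hetero atom and 1 hydrogen-bond donor, the leaving group one with 2 hetero atoms and 0 hydrogen-bond donors.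

Which of these differences carries the step stays open, since a piperazine ring set directly on the aromatic carbon would be needed to separate them. Also open, on these data alone, is whether a primary amine or a carboxylic acid in place of the methanesulfonamido group on the piperidine would stay at this limit.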